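From Phenyl to 3-Methoxyphenyl: The Step to Compound 4

The compounds below may be only part of what the source reports. "The series", "measured", "known", "first", "only" and "open" are said of these compounds alone.

Going by the values given here, in a functional assay on HeLa cells (Homo sapiens) for inhibition, read by MTT assay, with a stated time of 48 h (on this read-out higher numbers stand for weaker inhibition of growth and lower numbers for stronger inhibition of growth), compound 1 (`COc1ccc(C(=O)N2N=C(c3ccccc3)CC2c2cn(C)c3ccccc23)cn1`) gives 3980 nM and compound 3 (`COc1ccc2c(c1)c(C1CC(c3ccccc3)=NN1C(=O)c1ccc(OC)nc1)cn2C`) gives 1100 nM as the lower of the two exact numbers so far. Compound 2 (`COc1cc(C2=NN(C(=O)c3cccnc3)C(c3cn(C)c4ccc(Br)cc34)C2)cc(OC)c1OC`) reads > 10000 nM in this test, and that entry is a limit of the assay and not a number. This leaves compound 3 as the natural starting point for the next comparison.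

Compound 4 (`COc1cccc(C2=NN(C(=O)c3ccc(OC)nc3)C(c3cn(C)c4ccc(OC)cc34)C2)c1`) has not yet been measured. Compared with compound 3, it has methoxy in place of hydrogen on an aromatic carbon, so that phenyl becomes 3-methoxyphenyl (methoxy in place of hydrogen on an aromatic carbon).

Among the compounds with values here, one measured step bears on this change. The same kind of swap, made at another place in the molecule, gave a 3.6-fold lower number from compound 1 to compound 3 (0.56 log units; beyond the scatter) as a modest move towards stronger inhibition of growth. That single example points downward, but the new methoxy sits elsewhere, so its size need not carry over. A small downward step or none beyond the scatter is therefore the expectation, and the uncertainty remains wide in both directions.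

The estimate corresponds to an expected 1.2-fold lower number from compound 3 to compound 4 (0.09 log units; within the scatter) in this test. For compound 4 the estimated value is 900 nM with an expected range from 250 nM to 4000 nM in repeat measurements.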

Compound 4, concentration for 50% growth inhibition: 340 nM
Compound 4: middle estimate off by 2.6-fold (0.42 log units), on the high side, within the range that was stated.
By their numbers in this assay, from the lowest: compound 4; then compound 3; then compound 1. At a limit, above all of these: compound 2.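

In this assay, the phenyl ring had stayed unchanged between the compounds with exact numbers, and this result shows that it responds to substitution: the change from phenyl to 3-methoxyphenyl gives a 3.2-fold lower number from compound 3 to compound 4 (0.51 log units; beyond the scatter). The earlier step, a 3.6-fold lower number from compound 1 to compound 3 (0.56 log units; beyond the scatter), made the same kind of swap at another place, so methoxy in place of hydrogen on an aromatic carbon has now lowered the number at two places in this series, each time by a modest amount beyond the scatter, and compound 4 carries both methoxy groups. Nothing measured here explains why this change strengthens growth inhibition at either place.

The compounds compared here leave open whether this gain belongs to methoxy itself or would also appear with a different group on the same ring, such as a hydroxyl, a fluorine atom, an amine or a longer ether chain. They also leave open how much the position on the ring matters, since the one-place comparison at this ring covers only the 3-methoxyphenyl group and a single cell line.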